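Shortening the butyl amide chain to ethyl

A few compounds are considered here, and "the series" means these few. Any claim that something is new, unique, unknown or untested is made for them only; others in the source may bear on it.

Measured in a functional assay on K562 cells (Homo sapiens) for antiproliferative activity, read by CCK-8 assay, with a stated time of 72 h; a lower number here means a stronger inhibitor of growth, a higher number a weaker inhibitor of growth
compound 1 `CCC1C(=O)N(C)c2cnc(-n3ccc4cc(F)ccc43)nc2N1c1ccn(C)n1` gives 6070 nM
compound 2 `CCCCNC(=O)c1ccc2c(ccn2-c2ncc3c(n2)N(c2ccn(C)n2)C(CC)C(=O)N3C)c1` gives 14100 nM

Of these two, compound 2 stands highest at 14100 nM and is the weaker growth inhibitor, while compound 1 gives 6070 nM. Compound 3 `CCNC(=O)c1ccc2c(ccn2-c2ncc3c(n2)N(c2ccn(C)n2)C(CC)C(=O)N3C)c1` differs from compound 2 in one place: hydrogen in place of ethyl on a saturated chain carbon, two bonds along the chain from an amide-type nitrogen. This is hydrogen in place of ethyl on a saturated chain carbon, two bonds along the chain from an amide-type nitrogen, so that butyl becomes ethyl. For the measured compounds named here, only one measured step bears on this change: a 2.3-fold higher number from compound 1 to compound 2 (0.37 log units; beyond the scatter), with butylcarbamoyl in place of fluoro on an aromatic carbon. Going by the values given here, that step is modest, and it does not test chain length alone, since no measured pair differs only there. A small shift towards a lower number in this assay is therefore expected, probably within the scatter. The expected change is a 1.4-fold lower number from compound 2 to compound 3 (0.15 log units; within the scatter). For compound 3 the estimated value is 10000 nM, with an expected range from 4500 nM to 22000 nM.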

Compound 3, concentration for 50% growth inhibition: 12800 nM
Compound 3: middle estimate off by 1.3-fold (0.11 log units), on the low side; low and high end bracket the measured number.
By their numbers in this assay, from the lowest: compound 1; then compounds 3 and 2 (each within the scatter of the next).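

In this assay, shortening the amide chain from butyl to ethyl gives a 1.1-fold lower number from compound 2 to compound 3 (0.04 log units; within the scatter), so the compounds shown draw no distinction between these two chain lengths at this position. Compound 1 with its fluoro group remains apart from both amides: ethylcarbamoyl in place of fluoro gives a 2.1-fold higher number from compound 1 to compound 3 (0.32 log units; beyond the scatter), and butylcarbamoyl in place of fluoro gives a 2.3-fold higher number from compound 1 to compound 2 (0.37 log units; beyond the scatter), so both chains sit on the same side of compound 1 and both steps lie beyond the scatter. No independent measurement bears on the reason for these numbers.

Only the butyl and ethyl amides are shown, so it remains open whether a methyl amide, a primary carboxamide or a much longer chain such as octyl would also stay within the scatter of compound 3 or would separate from it. Going by these compounds, it is equally open how a carboxylic acid, an amine or a nitrile on that same aromatic carbon would read against compound 1, which has the lowest number of the three in this assay.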